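A few compounds are considered here, and "the series" means these few. Any claim that something is new, unique, unknown or untested is made for them only; others in the source may bear on it.

Compound 2, `CSc1ccccc1CNc1ncnn1-c1cccc(Cl)c1Cl`, gives 288 nM in a functional assay for antagonist activity at P2X purinoceptor 7 (Rattus norvegicus), read by FLIPR and calcium flux; a lower number here means a stronger inhibitor, a higher number a weaker inhibitor. Within the data shown here, of the two compounds measured so far it carries the higher number, yet its only neighbour, compound 1, `Cc1ccccc1CNc1ncnn1-c1cccc(Cl)c1Cl`, gives 200 nM in this assay, and the two values sit within the scatter of each other. Compound 3, `CS(=O)(=O)c1ccccc1CNc1ncnn1-c1cccc(Cl)c1Cl`, differs from compound 2 in one place: methylsulfonyl in place of methylsulfanyl on an aromatic carbon. Among the measured compounds shown here, only one measured step touches this position, the exchange of methyl for methylsulfanyl, and it was a 1.4-fold higher number from compound 1 to compound 2 (0.16 log units; within the scatter), a change that does not stand out from the scatter. No measured pair here swaps a methylsulfanyl for a methylsulfonyl, so the size of the coming step has no direct precedent among the compounds shown. For the measured compounds named here, with the single change at this position having stayed small, a modest movement in this assay is expected, though the direction is not settled by the data. For compound 3 a value of 600 nM is estimated, with a range from 200 nM to 2000 nM, meaning an expected step of a 2.1-fold higher number from compound 2 to compound 3 (0.32 log units; beyond the scatter).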

Compound 3, half-maximal inhibitory concentration: 39.8 nM
Beside the measured number, compound 3's estimate is 15-fold (1.18 log units) above it; measured number below the stated range.
By their numbers in this assay, from the lowest: compound 3; then compounds 1 and 2 (each within the scatter of the next).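

In this assay, this position proves sensitive to the group it carries: methylsulfonyl in place of methylsulfanyl produces a clear gain (in numbers, a 7.2-fold lower number from compound 2 to compound 3 (0.86 log units; beyond the scatter)), whereas the earlier exchange of methyl for methylsulfanyl stayed small (a 1.4-fold higher number from compound 1 to compound 2 (0.16 log units; within the scatter)). The same group also stands apart from methyl (a 5.0-fold lower number from compound 1 to compound 3 (0.70 log units; beyond the scatter)), so compound 3 carries the lowest number of the three, with both of its steps beyond the scatter, while compound 1 and compound 2 remain within the scatter of each other. The compounds therefore show that the outcome at this position is not the same for every small group, but nothing presented here explains why methylsulfonyl behaves differently.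

The compounds shown leave open whether an intermediate methylsulfinyl group would give a number nearer to compound 2 or to compound 3, and whether a longer ethylsulfonyl chain or a sulfonamide would keep the gain. They also leave open how unrelated groups such as a nitrile, an amide or a carboxylic acid would fare on this aromatic carbon in this assay.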